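The source may report more compounds than this note shows. Statements on the series, on what has been measured and on what is new or still open speak of the compounds shown alone.

Compound 1 `CC1(C)C=C(n2ccccc2=O)c2ccccc2O1` carries only the shared core; in a functional assay (aorta) with Rattus norvegicus as the target (on this read-out lower numbers stand for lower potency and higher numbers for higher potency (the scale is a negative logarithm)), compound 1 gives 5.43. Compound 2 `CC1(C)C=C(n2ccccc2=O)c2cc(C=C(C#N)C#N)ccc2O1` gives 6.95, and compound 3 `CC1(C)C=C(n2ccccc2=O)c2cc(OS(=O)(=O)F)ccc2O1` gives 7.95, the highest of the three numbers, set apart by the step of a number 1.00 log units higher from compound 2 to compound 3 (beyond the scatter) and the step of a number 2.52 log units higher from compound 1 to compound 3 (beyond the scatter). The change to compound 4 `CC1(C)C=C(n2ccccc2=O)c2cc(Br)ccc2O1` is bromo in place of (fluorosulfonyl)oxy on an aromatic carbon. Among the measured compounds shown here, three measured steps bear on it: a number 1.52 log units higher from compound 1 to compound 2 (beyond the scatter), a number 2.52 log units higher from compound 1 to compound 3 (beyond the scatter) and a number 1.00 log units higher from compound 2 to compound 3 (beyond the scatter). For the measured compounds named here, each group placed on that aromatic carbon raised potency beyond the scatter, but no measured step shows bromo there. Compound 4 is expected to land between compound 1 and compound 3, so a step of a number 1.15 log units lower from compound 3 to compound 4 (beyond the scatter) is expected. The number for compound 4 in this assay is estimated at 6.8, with a range from 6 to 7.6.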

Compound 4, logarithm of the reciprocal of the active concentration, log(1/C): 7.84
Compound 4: the middle estimate sits 1.04 log units below what was measured; measured number outside the range, above it.
By their numbers in this assay, from the lowest: compound 1; then compound 2; then compounds 4 and 3 (each within the scatter of the next).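

Exchanging (fluorosulfonyl)oxy, with 5 heavy atoms and 3 hydrogen-bond acceptors, for bromo, with 1 heavy atom and 0 acceptors, gives a number 0.11 log units lower from compound 3 to compound 4 (within the scatter) and so no real change in potency. On this aromatic carbon, then, neither the larger group nor its acceptors are needed for the gain: bromo alone gives a number 2.41 log units higher from compound 1 to compound 4 (beyond the scatter) and also stands clear of 2,2-dicyanoethenyl, with a number 0.89 log units higher from compound 2 to compound 4 (beyond the scatter) as the step. Going by these compounds, whether an amine or a carboxylic acid on the same carbon would hold this potency stays open. Nothing measured here explains why bromo and (fluorosulfonyl)oxy match.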